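This account rests on a few compounds, and the source may have more. Where it says the series, first, only, none or still open, it means among the compounds named here.

Measured in a functional assay (strain AB) with Danio rerio as the target, read by microscopy, with a stated time of 1 h; a lower number here means that less compound is needed, a higher number that more compound is needed for the effect:
compound 1, `CCN1CCc2c(sc(NC(=O)Nc3ccc(Br)cc3)c2C(N)=O)C1`, 3130 nM;
compound 2, `CCN1CCc2c(sc(NC(=O)Nc3ccc(Cl)cc3)c2C(N)=O)C1`, 3120 nM;
compound 3, `COCCCN1CCc2c(sc(NC(=O)Nc3ccc(Cl)cc3)c2C(N)=O)C1`, 2400 nM.

Compound 2 has the second highest number of the three in this assay. Its nearest neighbour is compound 1, with a 1.0-fold lower number from compound 1 to compound 2 (0.00 log units; within the scatter), and its furthest is compound 3, with a 1.3-fold lower number from compound 2 to compound 3 (0.11 log units; within the scatter); both steps fall within the scatter, so the three measured compounds are indistinguishable on these numbers.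

Compound 4, `CCN1CCc2c(sc(NC(=O)Nc3ccc(Cl)cc3)c2C#N)C1`, differs from compound 2 in one place: cyano in place of carbamoyl on an aromatic carbon. Neither measured step bears on this change. The step with chloro in place of bromo and the step with methoxymethyl in place of hydrogen both sit away from the carbamoyl, and both stayed within the scatter; nothing measured shows how the shared core responds to exchanging the carbamoyl for a cyano. The expectation for compound 4 therefore rests on compound 2 alone, which gives 3120 nM, and it is held with wide uncertainty. Compound 4 is estimated at 4000 nM, within 1500 nM to 12000 nM, which means an expected 1.3-fold higher number from compound 2 to compound 4 (0.11 log units; within the scatter).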

Compound 4, half-maximal effective concentration: > 25000 nM
Compound 4: no number, only a limit; the forecaster's own chance of this, stated with the estimate: 10%; at least 6.2-fold (0.79 log units) between middle value and limit.
By their numbers in this assay, from the lowest: compounds 3, 2 and 1 (each within the scatter of the next). At a limit, above all of these: compound 4.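

In this assay, exchanging the carbamoyl for cyano on this aromatic carbon gives an at least 8.0-fold higher number from compound 2 to compound 4 (0.90 log units; beyond the scatter), the only step among those shown that lies beyond the scatter. The steps of chloro for bromo and of methoxymethyl for hydrogen, made elsewhere on the shared core, had left the number within the scatter, so this position is the first shown to respond to a change. The reading of compound 4 is a limit and not a number: the limit of > 25000 nM in this assay, at which 1 of the 4 values shown sits.

The compounds shown do not tell whether the step follows the loss of the hydrogen-bond donor or some other difference between the two groups. As far as these compounds go, a carboxylic acid or an N-methyl amide on the same aromatic carbon would bear on that question, and how far the number can move here remains unknown.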